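A few compounds are considered here, and "the series" means these few. Any claim that something is new, unique, unknown or untested is made for them only; others in the source may bear on it.

Measured in an ADME assay on L02 cells (Homo sapiens) for cytotoxicity, read by MTT assay, with a stated time of 24 h; on this read-out lower numbers stand for higher toxicity in this test and higher numbers for lower toxicity in this test:
Compound 1 `Cc1ccccc1-n1cc(-c2ccccc2NS(=O)(=O)c2c[nH]c(=O)[nH]c2=O)nn1` gives 56600 nM.
Compound 2 `Cc1ccc(-n2cc(-c3ccccc3NS(=O)(=O)c3c[nH]c(=O)[nH]c3=O)nn2)cc1` reaches only the assay limit, > 100000 nM.
Compound 3 `O=c1[nH]cc(S(=O)(=O)Nc2ccccc2-c2cn(-c3cccc(F)c3)nn2)c(=O)[nH]1` is recorded as "not toxic" (no number reported), with no number.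

Going by the values given here, the one step that carries a number, an at least 1.7-fold higher number from compound 1 to compound 2 (0.24 log units; that floor lies within the scatter), is only a floor that lies within the scatter, and it rests on (the limit of > 100000 nM in this assay, at which 1 of the 3 values shown sits). Among the compounds with values here, compound 3 stands without a number in this assay, so no step from it can be computed and its entry gives nothing to compare. Compound 4 `O=c1[nH]cc(S(=O)(=O)Nc2ccccc2-c2cn(-c3ccccc3Cl)nn2)c(=O)[nH]1` carries 2-chlorophenyl in place of 3-fluorophenyl on an aromatic nitrogen. Within the data shown here, no measured step joins compound 3 and compound 4, so the direction of this change is open. Compound 1 gives 56600 nM in this assay. Compound 2 sits at the assay limit. Compound 4 is expected near 70000 nM in this assay, within 25000 nM to 100000 nM.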

Compound 4, half-maximal cytotoxic concentration: 22800 nM
Compound 4: the middle estimate sits 3.1-fold (0.49 log units) above what was measured, outside the stated range (below it).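

In this assay, going by these compounds alone, swapping the group on the aromatic carbon of the 2-substituted phenyl gives the first change beyond the scatter, a 2.5-fold lower number from compound 1 to compound 4 (0.39 log units; beyond the scatter), with chloro in place of methyl. Compound 2 stands at a limit, so an at least 4.3-fold lower number from compound 2 to compound 4 (0.64 log units; beyond the scatter) is only a floor: the limit of > 100000 nM in this assay, at which 1 of the 4 values shown sits.

Steps involving compound 3 cannot be read, so the 3-fluorophenyl and 2-chlorophenyl groups stay unranked. Going by these compounds, how an amine or a carboxylic acid in place of the chloro would read remains open.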